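The source may hold more compounds than are shown below. What is called first, only, known or untested is meant among the compounds shown, and "the series" means these compounds.

Compounds measured so far:

- compound 1, `COc1cc(OC)cc(N2CCN(C(=O)c3onc(C)c3-c3ccc(-c4ccco4)cc3)CC2)c1`: 191 nM
- compound 2, `Cc1nc(-c2ccccc2F)c(C(=O)N2CCN(c3cc(Cl)ccc3C)CC2)o1`: 229 nM
- compound 3, `CCc1nc(-c2ccccc2F)c(C(=O)N2CCN(c3cccc(OC)c3)CC2)o1`: 607 nM

In a functional assay on HL-60 cells (Homo sapiens) for inhibition, read by MTT assay, with a stated time of 72 h (on this read-out lower numbers stand for stronger inhibition and higher numbers for weaker inhibition), compound 1 gives the lowest of the three numbers. Its nearest neighbour is compound 2, whose value lies within the usual scatter of compound 1, so no order between those two can be claimed. Compound 3 stands furthest away, with a gap beyond the scatter, so compound 1 and compound 2 both inhibit more strongly than compound 3 in this assay.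

The unmeasured compound 4, `COc1cc(OC)cc(N2CCN(C(=O)c3onc(C)c3-c3ccccc3F)CC2)c1`, keeps the core of compound 1 and the same piperazine-linked aryl group, and differs only at one aromatic carbon of that core: 2-fluorophenyl in place of 4-(furan-2-yl)phenyl on an aromatic carbon. The 2-fluorophenyl group that enters is the same group carried by compound 2 and compound 3, though on a different core, and those two show that it is compatible with inhibition at the level of compound 1 or somewhat weaker.

Among the measured compounds shown here, no measured pair isolates this exact change, so the expectation is a modest step towards weaker inhibition, a 1.8-fold higher number from compound 1 to compound 4 (0.26 log units; within the scatter), possibly no more than the scatter. Compound 4 is therefore estimated at 350 nM, with a range from 120 nM to 1000 nM.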

Compound 4, half-maximal inhibitory concentration: 165 nM
Compound 4: middle estimate off by 2.1-fold (0.33 log units), on the high side; the range from low to high includes it.
By their numbers in this assay, from the lowest: compounds 4, 1 and 2 (each within the scatter of the next); then compound 3.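

In this assay the exchange gives a 1.2-fold lower number from compound 1 to compound 4 (0.06 log units; within the scatter) and so shows that, on this aromatic carbon of the five-membered ring, 2-fluorophenyl can take the place of 4-(furan-2-yl)phenyl without a change that can be told from the scatter. The earlier compounds shown here could not show this, since none of them formed a pair differing in one place; here the group shrinks from 11 heavy atoms to 7 and loses one of its two aromatic rings and its hydrogen-bond acceptor, yet the read-out stays level. Nothing at hand gives a measured reason for this outcome.

What the compounds leave open is how much of the entering group is needed at this position: an unsubstituted phenyl would separate the fluorine from the ring that carries it, and a small chain such as ethyl would test whether an aromatic ring is needed there at all. Also open, on these data alone, is how this position responds to a group of another kind, such as a carboxylic acid or an amine on the phenyl ring.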